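Series notes: adding a methoxy to compound 3

The source may hold more compounds than are shown below. What is called first, only, known or untested is meant among the compounds shown, and "the series" means these compounds.

Measured so far, in a functional assay on MOLT-4 cells (Homo sapiens) for antiproliferative activity, read by cell counting, with a stated time of 2 days; a lower number here means a stronger inhibitor, a higher number a weaker inhibitor:
- compound 1 `COc1ccc(C(=O)c2sc(Nc3ccccc3)nc2N)cc1OC`: 5500 nM
- compound 2 `Cc1ccc(Nc2nc(-n3ccnc3C)cs2)cc1`: 510 nM
- compound 3 `COc1cccc(C(=O)c2sc(Nc3ccccc3)nc2N)c1`: 1300 nM

Compound 3 stands second highest of the three numbers. Its nearest neighbour is compound 2, whose value is the lower one; the furthest is compound 1, whose value is the higher one. For the measured compounds named here, no single-point step links compound 2 and compound 3, so only their two values can be compared. Going by the values given here, the one single-point step within the set is a 4.2-fold lower number from compound 1 to compound 3 (0.63 log units; beyond the scatter), a modest step that came from removing a methoxy from the ring carrying the carbonyl.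

Compound 4 `COc1ccc(Nc2nc(N)c(C(=O)c3cccc(OC)c3)s2)cc1` differs from compound 3 by methoxy in place of hydrogen on an aromatic carbon, on the other aromatic ring, para to a large group. Among the compounds with values here, the step from compound 1 to compound 3 is the only one bearing on this change, and it runs the other way: taking a methoxy off lowered the number. Putting one on, at a different place, is therefore expected to raise the number somewhat or to leave it within the scatter. The expected step is a 1.4-fold higher number from compound 3 to compound 4 (0.14 log units; within the scatter). Compound 4 is estimated at 1800 nM, in the range 700 nM to 4500 nM, in this assay .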

Compound 4, half-maximal inhibitory concentration: 4 nM
The estimate for compound 4 lay 450-fold (2.65 log units) above the measured number, outside the stated range (below it).
By their numbers in this assay, from the lowest: compound 4; then compound 2; then compound 3; then compound 1.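

In this assay, the change from phenyl to 4-methoxyphenyl gives a 330-fold lower number from compound 3 to compound 4 (2.51 log units; beyond the scatter), which shows that this place, on the aromatic ring of carbon only and para to a large group, is highly sensitive to the added methoxy. For the compounds shown here, the only earlier step concerned the ring carrying the carbonyl, where a 4.2-fold lower number from compound 1 to compound 3 (0.63 log units; beyond the scatter) came with losing a methoxy, so a methoxy there goes with a higher number and a methoxy at the new place with a much lower one: the outcome of this change depends on the ring it is made on, at least across these two steps. No measurement to hand explains the size of the new step or the opposite directions of the two steps.

The compounds shown leave open whether the drop belongs to methoxy itself or would also appear with a fluorine, a hydroxyl or an ethoxy at the same place. Also open, as far as these compounds go, is how far the number of compound 4 relies on the methoxy of the ring carrying the carbonyl, and whether a second methoxy on that ring would raise the number here as it does between compound 3 and compound 1.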